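The compounds below may be only part of what the source reports. "The series", "measured", "known", "first", "only" and "open" are said of these compounds alone.

Compounds measured in a functional assay on CEM-SS cells (Homo sapiens) for cytotoxicity; on this read-out higher numbers stand for lower toxicity in this test and lower numbers for higher toxicity in this test:
- compound 1 `NC(CO[C@@H]1O[C@H](CO)[C@H](O)[C@H](O)[C@H]1O)C(=O)NCCCCCCCCCCCC(=O)O`: > 100000 nM
- compound 2 `CCCCCCCCCCCCCCNC(=O)C(CO[C@@H]1O[C@H](CO)[C@H](O)[C@H](O)[C@H]1O)NC(=O)CCCCCCCCCCC(=O)O`: > 100000 nM
- compound 3 `O=C(O)CCCCCCCCCCC(=O)N(CCCCCCCC(F)(F)C(F)(F)C(F)(F)C(F)(F)C(F)(F)C(F)(F)C(F)(F)C(F)(F)F)CCO[C@@H]1O[C@H](CO)[C@H](O)[C@H](O)[C@H]1O`: > 18000 nM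

All three entries are limits of the test, not numbers. Compound 1 therefore has no exact value, and its position is this: the limit of > 100000 nM in this assay, at which 2 of the 3 values shown sit. Compound 3 stands at a different limit: the limit of > 18000 nM in this assay, at which 1 of the 3 values shown sits. Going by the values given here, no compound here has yet given an exact half-maximal cytotoxic concentration.

Compound 4 `O=C(O)CCCCCCCCCCCNC(=O)C(CO[C@@H]1O[C@H](CO)[C@H](O)[C@H](O)[C@H]1O)NC(=O)CCC(=O)O` comes from compound 1 by a single change: (2-carboxyethyl)carbonyl in place of hydrogen on an amine nitrogen. Put simply, (2-carboxyethyl)carbonyl takes the place of hydrogen on an amine nitrogen.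

Among the compounds with values here, no measured pair shows what a step of this kind does, so the expectation is cautious. In this assay, the expected step of a number no higher from compound 1 to compound 4 (the limit leaves the size open) is none beyond the scatter, with no direction favoured. This expectation rests on compound 1, whose limit is > 100000 nM. For compound 4 the estimate is 100000 nM, with an expected range of 50000 nM to 200000 nM.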

Compound 4, half-maximal cytotoxic concentration: > 100000 nM
Compound 4: a limit, no number; the forecaster's own chance of this, stated with the estimate: 90%; the middle value sits exactly at the limit.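

Going by these compounds alone, compound 1 and compound 4 both stop at a limit of the test in this assay, and no step from one to the other can be read. The compounds shown leave open what exact half-maximal cytotoxic concentration any of them has, and whether (2-carboxyethyl)carbonyl in place of hydrogen on an amine nitrogen changes it at all.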